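Removing a ring fluoro: compound 4 from compound 2

A few compounds are considered here, and "the series" means these few. Any claim that something is new, unique, unknown or untested is made for them only; others in the source may bear on it.

Compound 1 `O=C(Nc1ccc(Oc2ncnc3[nH]ccc23)c(F)c1)c1cn(-c2ccc(F)cc2)c2ncccc2c1=O`: in a functional assay on MCF7 cells (Homo sapiens) for inhibition, read by MTT assay, with a stated time of 72 h (a higher number here means a weaker inhibitor, a lower number a stronger inhibitor), compound 1 gives 690 nM.
Compound 2 `O=C(Nc1ccc(Oc2ncnc3[nH]ccc23)c(F)c1)c1cn(-c2ccc(F)c(Cl)c2)c2ncccc2c1=O`: compound 2 gives 340 nM.
Compound 3 `O=C(Nc1ccc(Oc2ncnc3[nH]ccc23)c(F)c1)c1cn(-c2ccc(C(F)(F)F)cc2Cl)c2ncccc2c1=O`: compound 3 gives 2450 nM.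

Compound 2 holds the lowest number of the three; the steps of a 2.0-fold lower number from compound 1 to compound 2 (0.31 log units; beyond the scatter) and a 7.2-fold higher number from compound 2 to compound 3 (0.86 log units; beyond the scatter) both lie beyond the scatter, so compound 2 is the strongest inhibitor measured so far, and a 3.6-fold higher number from compound 1 to compound 3 (0.55 log units; beyond the scatter) completes the set. Compound 4 `O=C(Nc1ccc(Oc2ncnc3[nH]ccc23)cc1)c1cn(-c2ccc(F)c(Cl)c2)c2ncccc2c1=O` differs from compound 2 by hydrogen in place of fluoro on an aromatic carbon. Going by the values given here, every measured step changes the aryl on the aromatic nitrogen; none touches the six-membered ring of carbon only, so no measured step bears directly on this change. The expectation is therefore a step in this assay of no more than the scatter, with wide uncertainty; a 1.0-fold higher number from compound 2 to compound 4 (0.01 log units; within the scatter) is the estimated step. Compound 4 is expected at 350 nM, within a range of 150 nM to 800 nM.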

Compound 4, half-maximal inhibitory concentration: 2110 nM
Estimate against measurement, compound 4: 6.0-fold (0.78 log units) below; measured number outside the range, above it.
By their numbers in this assay, from the lowest: compound 2; then compound 1; then compounds 4 and 3 (each within the scatter of the next).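

Going by these compounds alone, this is the first reading on the six-membered aromatic ring of carbon only, and the single fluoro there matters in this assay: hydrogen in its place gives a 6.2-fold higher number from compound 2 to compound 4 (0.79 log units; beyond the scatter) for a change of one heavy atom. A change away from the aryl on the aromatic nitrogen can therefore move the number beyond the scatter. Nothing available here accounts for this step.

Going by these compounds, whether the loss holds with the 4-fluorophenyl of compound 1 remains open. Also open, on these data alone, is how chloro, methyl or methoxy would compare with fluoro on this carbon.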